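Two Chloro Additions on a Shared Core

A few compounds are considered here, and "the series" means these few. Any claim that something is new, unique, unknown or untested is made for them only; others in the source may bear on it.

Compound 1 `COc1ccc(-c2nn(-c3ccccc3)cc2C(=O)NOCc2ccccc2Cl)cc1` carries a 4-methoxyphenyl group on one side of its core and a 2-chlorobenzyl group on the other. In an ADME assay on HEK-293T cells (Homo sapiens) for antiproliferative activity, read by MTT assay, with a stated time of 48 h, in the presence of a further agent that is not named here (a higher number here means that more compound is tolerated, a lower number that less compound is tolerated), compound 1 gives 586000 nM. Compound 2 `COc1ccc(-c2nn(-c3ccccc3)cc2C(=O)NOCc2ccc(Cl)cc2Cl)cc1` differs from compound 1 by chloro in place of hydrogen on an aromatic carbon; the step is a 1.1-fold lower number from compound 1 to compound 2 (0.03 log units; within the scatter), so the two numbers cannot be told apart. Compound 3 `O=C(NOCc1ccccc1Cl)c1cn(-c2ccccc2)nc1-c1ccc(Cl)cc1` rests on a different core, which differs from the core of compound 1 by chloro in place of methoxy on an aromatic carbon. In this assay compound 3 gives 129000 nM, and the step is a 4.5-fold lower number from compound 1 to compound 3 (0.66 log units; beyond the scatter). Compound 2 gives 545000 nM in this assay, and the number of compound 3 is the lowest of the three measured here, meaning that the cells tolerate the least of compound 3.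

Compound 4 `O=C(NOCc1ccc(Cl)cc1Cl)c1cn(-c2ccccc2)nc1-c1ccc(Cl)cc1` has not yet been measured. It differs from compound 3 by chloro in place of hydrogen on an aromatic carbon, the same change that leads from compound 1 to compound 2, made at the same place on the 2-chlorobenzyl group. On the core of compound 1 that change moved the number by a 1.1-fold lower number from compound 1 to compound 2 (0.03 log units; within the scatter), which stays within the scatter. Within the data shown here, whether the core of compound 3 answers in the same way is not known from these data; the one earlier step is the only guide. The step from compound 3 is therefore expected to be a 1.1-fold lower number from compound 3 to compound 4 (0.03 log units; within the scatter), resting on compound 1 and compound 2 showing a 1.1-fold lower number from compound 1 to compound 2 (0.03 log units; within the scatter). Compound 4 is estimated at 120000 nM in this assay, with a likely range from 60000 nM to 250000 nM.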

Compound 4, half-maximal cytotoxic concentration: 46300 nM
Beside the measured number, compound 4's estimate is 2.6-fold (0.41 log units) above it, and the stated range ends above it.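

On the core of compound 3, the added chloro that turns the 2-chlorobenzyl group into a 2,4-dichlorobenzyl group gives a 2.8-fold lower number from compound 3 to compound 4 (0.45 log units; beyond the scatter), yet this step cannot be told apart from the one seen on the core of compound 1: the same change on two cores in this assay, a 1.1-fold lower number (0.03 log units; within the scatter) from compound 1 to compound 2 and a 2.8-fold lower number (0.45 log units; beyond the scatter) from compound 3 to compound 4, 2.6-fold (0.41 log units) apart, within the scatter of two such steps. Chloro in place of methoxy, read with the 2,4-dichlorobenzyl group in place, gives a 12-fold lower number from compound 2 to compound 4 (1.07 log units; beyond the scatter), and this step also agrees with the one read with the 2-chlorobenzyl group: the same change on two cores in this assay, a 4.5-fold lower number (0.66 log units; beyond the scatter) from compound 1 to compound 3 and a 12-fold lower number (1.07 log units; beyond the scatter) from compound 2 to compound 4, 2.6-fold (0.41 log units) apart, within the scatter of two such steps. In this assay, among these compounds, each change therefore carries from one setting to the other within the scatter, but each comparison rests on only two steps, so this does not show that the added chloro acts differently on the two cores, nor that the agreement extends beyond these four compounds.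

The compounds shown leave open whether a fluoro or a methyl group in place of the added chloro would follow the same steps. They also leave open whether an amine or a carboxylic acid in place of the methoxy group would carry from one benzyl group to the other in the same way.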